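Thiophene to chlorophenyl on the sulfonyl of two cores

This account rests on a few compounds, and the source may have more. Where it says the series, first, only, none or still open, it means among the compounds named here.

Measured in a functional assay on MCF7 cells (Homo sapiens) for cytotoxicity, with a stated time of 96 h; a higher number here means a weaker inhibitor of growth, a lower number a stronger inhibitor of growth:
- compound 1 `O=C(Oc1cccc2cccnc12)c1cc2c(cc1Cl)SC(N(c1ccc(F)cc1)S(=O)(=O)c1ccc(Br)s1)=NS2(=O)=O`: 3200 nM
- compound 2 `COC(=O)c1cc2c(cc1Cl)SC(N(N(C)C)S(=O)(=O)c1ccc(Br)s1)=NS2(=O)=O`: 10900 nM
- compound 3 `O=C(Oc1cccc2cccnc12)c1cc2c(cc1Cl)SC(N(c1ccc(F)cc1)S(=O)(=O)c1ccc(Cl)cc1)=NS2(=O)=O`: 3200 nM

Compound 1 and compound 3 share one core and differ only in 4-chlorophenyl in place of 5-bromothiophen-2-yl on a sulfonyl sulfur. This change gave no change at the digits printed from compound 1 to compound 3 (within the scatter). Compound 2 carries a different core; it differs from compound 1 in more than one place, and the difference between the two cores is not broken down here. In this assay compound 2 stands highest of the three, and its gap to compound 1 and to compound 3 lies beyond the scatter.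

Compound 4 `COC(=O)c1cc2c(cc1Cl)SC(N(N(C)C)S(=O)(=O)c1ccc(Cl)cc1)=NS2(=O)=O` is the counterpart of compound 3 on the core of compound 2: it differs from compound 2 by 4-chlorophenyl in place of 5-bromothiophen-2-yl on a sulfonyl sulfur, the same change as from compound 1 to compound 3, at the same place. From compound 2 to compound 4 a step of a 1.1-fold lower number from compound 2 to compound 4 (0.04 log units; within the scatter) is expected, because the same change gave no change at the digits printed from compound 1 to compound 3 (within the scatter) on the other core. Compound 4 is therefore estimated at 10000 nM, with a range from 4000 nM to 25000 nM.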

Compound 4, concentration for 50% growth inhibition: 8700 nM
Compound 4: middle estimate off by 1.1-fold (0.06 log units), on the high side, and the stated range covers the measured number.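

In this assay, putting 4-chlorophenyl in place of 5-bromothiophen-2-yl on the sulfonyl sulfur gave a 1.3-fold lower number from compound 2 to compound 4 (0.10 log units; within the scatter), so on this second core too the change made no difference that can be told from scatter. Compared across the two cores, the change behaved alike: the same change on two cores in this assay, no change at the digits printed (within the scatter) from compound 1 to compound 3 and a 1.3-fold lower number (0.10 log units; within the scatter) from compound 2 to compound 4, 1.3-fold (0.10 log units) apart, within the scatter of two such steps

Among these compounds, this shows that, for these two cores and this one cell assay, the change can be carried from one core to the other without a detectable effect on growth inhibition, but it rests on only two pairs, and because neither step is large, it does not show that a change with a real effect would carry over in the same way.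

The compounds shown leave open whether an open alkyl chain or a ring bearing an amine or a carboxylic acid on the sulfonyl sulfur would also leave the number in place. They also do not separate the several places in which the two cores differ, so it remains open which of them accounts for the gap in growth inhibition.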